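Aminobenzylidene series: moving the amine on the benzylidene ring

The source may hold more compounds than are shown below. What is called first, only, known or untested is meant among the compounds shown, and "the series" means these compounds.

Measured so far:
compound 1 `CC(C)(C)c1ccc(CN2C(=O)S/C(=C\c3ccc(N)cc3)C2=O)cc1` — 66000 nM
compound 2 `Nc1ccc(/C=C2\SC(=O)N(Cc3ccc(Cl)cc3)C2=O)cc1` — 87000 nM
compound 3 `Nc1cccc(/C=C2\SC(=O)N(Cc3cccc(F)c3)C2=O)c1` — 250000 nM

In a functional assay on CCRF-CEM cells (Homo sapiens) for cytotoxicity, read by cell counting, with a stated time of 3 days (a lower number here means a stronger inhibitor, a higher number a weaker inhibitor), compound 1 gives the lowest of the three numbers; compound 2 sits within the scatter of it, and compound 3 lies beyond the scatter, at a higher number. Going by the values given here, the only single-point step recorded, a 1.3-fold higher number from compound 1 to compound 2 (0.12 log units; within the scatter), concerns the benzyl ring and is within the scatter, so it says nothing about the aminophenyl ring.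

Compound 4 `CC(C)(C)c1ccc(CN2C(=O)S/C(=C\c3cccc(N)c3)C2=O)cc1` differs from compound 1 by 3-aminophenyl in place of 4-aminophenyl on a double-bonded chain carbon bound to a double-bonded ring carbon. Among the compounds with values here, no measured pair isolates this change. Compound 3 carries the 3-aminophenyl group, but it differs from compound 2 in two places, so its values against compounds 1 and 2 can only hint that the 3-aminophenyl compounds run toward higher numbers. Expectation for compound 4 is therefore a modest rise, a 2.0-fold higher number from compound 1 to compound 4 (0.29 log units; within the scatter), with wide uncertainty. Compound 4 is expected to give about 130000 nM in this assay, within 50000 nM to 350000 nM.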

Compound 4, half-maximal inhibitory concentration: 165000 nM
Estimate against measurement, compound 4: 1.3-fold (0.10 log units) below; measured number inside the range.
By their numbers in this assay, from the lowest: compounds 1, 2, 4 and 3 (each within the scatter of the next, the first and the last beyond it).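

Going by these compounds alone, with the tert-butyl benzyl group held fixed, this assay gives a 2.5-fold higher number from compound 1 to compound 4 (0.40 log units; beyond the scatter) as the first single-change reading at this position, and the step is modest but lies beyond the scatter. The groups 4-aminophenyl and 3-aminophenyl have the same atoms and the same counts, so this pair isolates where the amine sits on the ring from any change in composition. No measurement at hand bears on what lies behind the step.

Within the data shown here, whether the same step appears with the chlorinated benzyl group of compound 2 remains open, since only this one pair reads the change. Also open, going by these compounds, is how this assay would respond to a hydroxyl group or a dimethylamino group in place of the amine on this ring.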